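Furan-3-yl in Place of Ethynyl on Two Cores

A few compounds are considered here, and "the series" means these few. Any claim that something is new, unique, unknown or untested is made for them only; others in the source may bear on it.

Measured in a functional assay on HL-60 cells (Homo sapiens) for antiproliferative activity, read by XTT assay, with a stated time of 72 h; a lower number here means a stronger inhibitor, a higher number a weaker inhibitor:
compound 1 `CN(C)c1ncnc2c1c(-c1ccoc1)cn2[C@@H]1O[C@H](CO)[C@@H](O)[C@H]1O`: 1160 nM
compound 2 `C#Cc1cn([C@@H]2O[C@H](CO)[C@@H](O)[C@H]2O)c2ncnc(N(C)C)c12`: 290 nM
compound 3 `C#Cc1cn([C@@H]2O[C@H](CO)[C@@H](O)[C@H]2O)c2nc(N)nc(OC)c12`: only a limit of the assay, > 20000 nM

Among the measured compounds shown here, the one counted step among the measured compounds is furan-3-yl in place of ethynyl on an aromatic carbon, which gave a 4.0-fold higher number from compound 2 to compound 1 (0.60 log units; beyond the scatter). Compound 3 shares the ethynyl group of compound 2 but carries a different core; how the two cores differ is not broken down here. Compound 4 `COc1nc(N)nc2c1c(-c1ccoc1)cn2[C@@H]1O[C@H](CO)[C@@H](O)[C@H]1O` is to be measured in this assay, and it arises from compound 3 by furan-3-yl in place of ethynyl on an aromatic carbon, the same change as that from compound 2 to compound 1, at a place described in the same words.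

The expectation for compound 4 rests on two things: the earlier step of a 4.0-fold higher number from compound 2 to compound 1 (0.60 log units; beyond the scatter) raised the number, and compound 3 already sits at the limit of > 20000 nM in this assay, at which 1 of the 3 values shown sits. A further rise from a limit cannot be seen as a number. Compound 4 is therefore expected to return only a limit again, with an estimated midpoint of 60000 nM between 20000 nM and 200000 nM, an expected step that the limit leaves unreadable from compound 3 to compound 4.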

Compound 4, half-maximal inhibitory concentration: > 20000 nM
Compound 4 was reported as a limit; the forecaster's own chance of this, stated with the estimate: 90%; the middle value does not contradict the limit.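

In this assay compound 4 gave > 20000 nM as a limit of the assay. Among the compounds shown here, compound 3 gave > 20000 nM as a limit too, and no step between compound 3 and compound 4 can be read. The compounds shown leave open whether furan-3-yl in place of ethynyl changes the number on the core of compound 3 at all.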